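Longer chain on the ring amine: cytotoxicity in HEL cells

The compounds below may be only part of what the source reports. "The series", "measured", "known", "first", "only" and "open" are said of these compounds alone.

Compound 1 `CCCCCNc1nccnc1C(=O)NCc1ccccc1` gives >= 100000 nM in an ADME assay on HEL cells (Homo sapiens) for cytotoxicity, read by microscopy, with a stated time of 6 days; on this read-out lower numbers stand for higher toxicity in this test and higher numbers for lower toxicity in this test.
Compound 2 `CCCCNc1nccnc1C(=O)NCc1ccccc1` gives > 100000 nM in this assay.

Both values are limits of the test, not numbers. Within the data shown here, compound 2 therefore stands only at that limit in this assay, with no measured step that could show any difference from compound 1, since a step that the two limits leave unreadable from compound 1 to compound 2 is unreadable. Compound 3 `CCCCCCCCNc1nccnc1C(=O)NCc1ccccc1` carries butyl in place of hydrogen on a saturated chain carbon, four bonds along the chain from a nitrogen on an aromatic ring. No readable step bears on this change, so no size is expected beyond the scatter in this assay. Compound 3 is estimated at 80000 nM, between 20000 nM and 200000 nM. The step of an at least 1.2-fold lower number from compound 2 to compound 3 (0.09 log units; that floor lies within the scatter) is expected to be small, with a good chance of another limit.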

Compound 3, minimum cytotoxic concentration: > 100000 nM
Compound 3 was reported as a limit (the forecaster's own chance of this, stated with the estimate: 55%); middle value at least 1.2-fold (0.09 log units) away from the limit.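

Compound 1, compound 2 and compound 3 all stand at limits in this assay, and no step can be read among them. These compounds leave open whether the length of the chain changes cytotoxicity at all.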